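The source may report more compounds than this note shows. Statements on the series, on what has been measured and on what is new or still open speak of the compounds shown alone.

Compound 2, whose structure is `O=C(Nc1ccccc1Cl)C(Cl)Cl`, stands without a number: in a functional assay on Bel-7402 cells (Homo sapiens) for antiproliferative activity, read by MTT assay, with a stated time of 72 h (on this read-out higher numbers stand for weaker inhibition and lower numbers for stronger inhibition), compound 2 gives "not determined" (no result reported). The same holds for compound 1, `O=C(Nc1ccccc1)C(Cl)Cl`, for which this assay records "not determined" (no result reported). The only figure in the series belongs to compound 3, `O=C(Nc1ccccc1Br)C(Cl)Cl`, which in this assay gives 38200 nM. Compound 4, `O=C(Nc1ccccc1[N+](=O)[O-])C(Cl)Cl`, is related to compound 2 by a single exchange: nitro in place of chloro on an aromatic carbon. Within the data shown here, no measured pair in this set shows the effect of such an exchange, and with compound 2 itself unmeasured, no direction can be set for the step from compound 2 to compound 4 in this assay; the one anchor is the weak result of compound 3. On that basis compound 4 is expected to remain a weak inhibitor, with an estimated value of 30000 nM and a plausible range from 8000 nM to 120000 nM, a guess that rests only on compound 3 giving 38200 nM in this assay.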

Compound 4, half-maximal inhibitory concentration: 194000 nM
Compound 4: middle estimate off by 6.5-fold (0.81 log units), on the low side, outside the stated range (above it).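

In this assay, the exchange of bromo for nitro on this aromatic carbon gives a 5.1-fold higher number from compound 3 to compound 4 (0.71 log units; beyond the scatter), the first comparison the series allows, and it lies beyond the usual scatter. It shows that the group at this place matters for the read-out even within this weak range: of the two compounds with numbers, the one carrying nitro inhibits less strongly. No measurement at hand accounts for the difference. Steps involving compound 1 and compound 2 cannot be read, so the hydrogen of compound 1 and the chloro of compound 2 remain unplaced against bromo and nitro. Also open, going by these compounds, is where an amine or a carboxylic acid on this aromatic carbon would fall relative to compound 3 and compound 4.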